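The source may report more compounds than this note shows. Statements on the series, on what has been measured and on what is new or still open speak of the compounds shown alone.

Series notes. Compound 1 `CN(C)c1nc(/C=C/c2ccccc2)nc2ccsc12` and compound 2 `CNc1nc(/C=C/c2cc(OC)c(OC)c(OC)c2)nc2ccsc12` share one core and are both read in a functional assay on L02 cells (Homo sapiens) for inhibition, read by Griess assay, with stated times of 1 h and 24 h; on this read-out higher numbers stand for weaker inhibition and lower numbers for stronger inhibition. In this assay compound 1 returns only a limit, > 1000000 nM, and no number. Compound 2 likewise stands at a limit in this assay, > 1000000 nM, with nothing resolved beneath it. Both values shown therefore rest at the limit of > 1000000 nM in this assay, at which 2 of the 2 values shown sit. Compound 3 `COc1cc(/C=C/c2nc(NC(C)C)c3sccc3n2)cc(OC)c1OC` is not yet measured in this assay; it differs from compound 2 by isopropyl in place of methyl on a nitrogen on an aromatic ring. Within the data shown here, no step between measured compounds is on hand, and the only anchor for compound 3 is a boundary rather than a number. The step expected in this assay is a number no higher from compound 2 to compound 3 (the limit leaves the size open), that is, none beyond the scatter, with a fair chance that only a limit is again reported. Compound 3 is accordingly estimated at 1000000 nM, with a range from 300000 nM to 3000000 nM.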

Compound 3, half-maximal inhibitory concentration: > 1000000 nM
Compound 3: only a limit was reported; the forecaster's own chance of this, stated with the estimate: 80%; the middle value sits exactly at the limit.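

No step can be read from compound 2 to compound 3 in this assay, since each gives only a limit and no number: the limit of > 1000000 nM in this assay, at which 3 of the 3 values shown sit.

The compounds shown leave open how isopropyl and methyl on the nitrogen compare, and whether any change to the shared core brings a resolved value in this assay.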